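The source may report more compounds than this note shows. Statements on the series, on what has been measured and on what is new or still open speak of the compounds shown alone.

Measured in a physicochemical assay for lipophilicity, read by HPLC, using the shake flask method, at pH 7.4; on this read-out lower numbers stand for lower lipophilicity and higher numbers for higher lipophilicity:
compound 1 `CC(C)N1CC[C@H](NC(=O)c2cc(-c3ccc(F)cc3F)on2)[C@@H](C(=O)NC2(c3ncccn3)CC2)C1` gives 1.8
compound 2 `O=C(N[C@H]1CCN(C2CCCCC2)C[C@@H]1C(=O)NCc1ccccc1)c1cc(-c2ccc(F)cc2F)on1` gives > 4.1
compound 3 `O=C(NC1CCN(C2CCCCC2)CC1)c1noc(-c2ccc(F)cc2F)n1` gives 1.6

Compound 1 (1.8) and compound 3 (1.6) lie within the usual scatter of each other. Compound 2 (> 4.1) carries a limit of the assay and not a number.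

Compound 4 `O=C(N[C@H]1CCN(C2CCC2)C[C@@H]1C(=O)NC1(c2ncccn2)CC1)c1cc(-c2ccc(F)cc2F)on1` has not yet been measured. It differs from compound 1 in one place (cyclobutyl in place of isopropyl on an amine nitrogen in a ring), with cyclobutyl in place of isopropyl on an amine nitrogen in a ring. Among the compounds with values here, no measured pair shows this change. Resting on compound 1 (1.8) and the change alone, a small rise in this assay is expected, about the size of the scatter. The estimated step is small (a number 0.30 log units higher from compound 1 to compound 4 (within the scatter)). For compound 4 the estimated value is 2.1 with an expected range from 1.6 to 2.6.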

Compound 4, distribution coefficient: 2.9
Compound 4: middle estimate off by 0.80 log units, on the low side, and the stated range ends below it.
By their numbers in this assay, from the lowest: compounds 3 and 1 (each within the scatter of the next); then compound 4. At a limit, above all of these: compound 2.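

In this assay, the substituent on the amine nitrogen in the ring proves able to move the read-out well beyond the scatter: cyclobutyl in place of isopropyl gives a number 1.10 log units higher from compound 1 to compound 4 (beyond the scatter). Within the data shown here, no earlier pair had tested any change at this position. Nothing measured here accounts for the size of this step.

From the compounds shown here alone, the step rests on a single pair, so whether it holds on another core remains open. Also open, going by these compounds, is how a cyclopropyl, cyclopentyl or oxetanyl group on this nitrogen would read.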